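A few compounds are considered here, and "the series" means these few. Any claim that something is new, unique, unknown or untested is made for them only; others in the source may bear on it.

Of the compounds shown here, three built on a shared core have been tested in a functional assay on L1210 cells (Mus musculus), with a stated time of 12 days; a higher number here means a more potent compound, by a factor of ten per unit of this negative logarithm, a lower number a less potent compound. Compound 1 `CC1=C(N2CC2)C(=O)C(CC(C)OC(N)=O)=C(N2CC2)C1=O` gives 5.79, compound 2 `CC1=C(N2CC2)C(=O)C(C(C)COC(N)=O)=C(N2CC2)C1=O` gives 5.71, and compound 3 `CC1=C(N2CC2)C(=O)C(N2CC2)=C(N2CC2)C1=O` gives 6.21, the highest of the three. The step of a number 0.42 log units higher from compound 1 to compound 3 (beyond the scatter) and the step of a number 0.50 log units higher from compound 2 to compound 3 (beyond the scatter) both bring in aziridin-1-yl in place of a larger chain, while a number 0.08 log units lower from compound 1 to compound 2 (within the scatter) changes little. Compound 4 `CC1=C(N2CC2)C(=O)C(Cc2ccccc2)=C(N2CC2)C1=O` goes the opposite way: benzyl in place of aziridin-1-yl on a double-bonded ring carbon. Because the step of a number 0.42 log units higher from compound 1 to compound 3 (beyond the scatter) and the step of a number 0.50 log units higher from compound 2 to compound 3 (beyond the scatter) were both gains on bringing in aziridin-1-yl, removing it is expected to cost a modest amount, about a number 0.61 log units lower from compound 3 to compound 4 (beyond the scatter). Compound 4 is therefore estimated at 5.6, likely between 5.1 and 6.1.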

Compound 4, logarithm of the reciprocal of the active concentration, log(1/C): 4.69
Beside the measured number, compound 4's estimate is 0.91 log units above it; the whole stated range lies above it.
By their numbers in this assay, from the lowest: compound 4; then compounds 2 and 1 (each within the scatter of the next); then compound 3.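

In this assay, for the compounds shown here, putting benzyl at this double-bonded ring carbon gives a number 1.52 log units lower from compound 3 to compound 4 (beyond the scatter), so this position can lose far more than the earlier steps suggested. Benzyl also falls short of the open chains, with a number 1.02 log units lower from compound 2 to compound 4 (beyond the scatter) and a number 1.10 log units lower from compound 1 to compound 4 (beyond the scatter). Losing aziridin-1-yl therefore does not set the outcome alone: what enters in its place matters too. No measurement at hand explains this difference. Still open, on these data alone, is where an amine or a longer plain carbon chain at this place would fall relative to compound 3 and compound 4.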